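This account rests on a few compounds, and the source may have more. Where it says the series, first, only, none or still open, it means among the compounds named here.

Measured compounds:
Compound 1 `CC(C)(CCCC/C=C(/c1ccccc1)c1cccnc1)C(=O)O` — 38 nM
Compound 2 `O=C(O)CCCCCCCCC/C=C(/c1ccccc1)c1cccnc1` — 520 nM
Compound 3 `O=C(O)C(CCC/C=C(\c1ccccc1)c1cccnc1)C1(O)CCCC1` — 65 nM

In an assay (Equus caballus) for inhibition of Thromboxane-A synthase (Homo sapiens), using microsomes (on this read-out higher numbers stand for weaker inhibition and lower numbers for stronger inhibition), compound 1 gives the lowest of the three numbers; compound 3 lies within the scatter of it, while compound 2 lies beyond. Among the measured compounds shown here, the one counted step, a 14-fold higher number from compound 1 to compound 2 (1.14 log units; beyond the scatter), concerns the acid-bearing end of the chain and not the double bond.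

Compound 4 `CC(C)(CCCC/C=C(\c1ccccc1)c1cccnc1)C(=O)O` differs from compound 1 as follows: the two compounds have the same atoms and bonds and differ only in configuration as drawn: 1 of 1 stereo elements differ; a double bond is drawn Z in compound 1 and E in compound 4. For the measured compounds named here, no measured step probes the drawn configuration of the double bond, so the direction of the change is open; compound 1 and compound 3, whose values are within the scatter of each other, carry other differences as well. The expected step is a 3.2-fold higher number from compound 1 to compound 4 (0.50 log units; beyond the scatter), a modest weakening with wide uncertainty, giving an estimate for compound 4 of 120 nM (range 30 nM to 600 nM).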

Compound 4, half-maximal inhibitory concentration: 45 nM
Beside the measured number, compound 4's estimate is 2.7-fold (0.43 log units) above it; the measured number falls inside the stated range.
By their numbers in this assay, from the lowest: compounds 1, 4 and 3 (each within the scatter of the next); then compound 2.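

In this assay, this pair gives a direct reading of the drawn configuration of the double bond, with a 1.2-fold higher number from compound 1 to compound 4 (0.07 log units; within the scatter). With the 1-carboxy-1-methylethyl end held fixed, the Z and E drawings are therefore not told apart on this read-out. The reading belongs to the double bond alone: the fact that compounds 1 and 4 differ only in the configuration as drawn.

As far as these compounds go, it remains open whether Z and E also read alike with the 5-carboxypentyl chain of compound 2. From the compounds shown here alone, it is also open how an amide or a primary alcohol in place of the carboxylic acid would read on either geometry.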